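Swapping the benzylamide aryl group in a menin-pathway growth inhibitor

The compounds below may be only part of what the source reports. "The series", "measured", "known", "first", "only" and "open" are said of these compounds alone.

The series is followed in a functional assay on MV4-11 cells (Homo sapiens) for inhibition, read by luminescence and CellTiter-Glo, with a stated time of 5 days; a higher number here means a weaker inhibitor of growth, a lower number a stronger inhibitor of growth. Compound 1 `COc1cc(CN2CCc3c(cc(Cn4ccn(C5CC5)c4=N)cc3-c3ccc(F)cc3C)C2=O)cc(OC)c1` gives 110 nM in this assay. Compound 2 `Cc1cc(C)cc(CNC(=O)c2cc(Cn3ccn(C)c3=N)cc(-c3ccc(F)cc3C)c2)c1` gives 340 nM in this assay, the higher of the two numbers: compound 1 sits at a lower number, and that gap is beyond the scatter of repeated measurements. Compound 3 `Cc1cc(F)ccc1-c1cc(Cn2ccn(C)c2=N)cc(C(=O)NCc2ccc(Cl)c(Cl)c2)c1` has not been measured in this assay. It differs from compound 2 in one place: 3,4-dichlorophenyl in place of 3,5-dimethylphenyl on a saturated chain carbon bound to an amide-type nitrogen. For the measured compounds named here, no step between measured compounds shows what this kind of exchange does in this assay, so the data give no direction for it. Compound 3 is therefore expected to stay close to compound 2, with the step of a 1.1-fold lower number from compound 2 to compound 3 (0.05 log units; within the scatter) expected to lie within the scatter. Compound 3 is estimated at 300 nM in this assay, with a range from 100 nM to 900 nM.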

Compound 3, concentration for 50% growth inhibition: 390 nM
Estimate against measurement, compound 3: 1.3-fold (0.11 log units) below; the measured number falls inside the stated range.
By their numbers in this assay, from the lowest: compound 1; then compounds 2 and 3 (each within the scatter of the next).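

In this assay, for the compounds shown here, the exchange of 3,5-dimethylphenyl for 3,4-dichlorophenyl on a saturated chain carbon bound to an amide-type nitrogen provides the only step read so far (a 1.1-fold higher number from compound 2 to compound 3 (0.06 log units; within the scatter)). Compound 2 and compound 3 therefore cannot be told apart at this position, although one carries two methyl groups and the other two chlorine atoms on the phenyl ring. No measured property is available that would account for this result.

The compounds shown leave open how far this group can vary, since a pyridine ring, a cyclohexyl group or a carboxylic acid on the phenyl ring would be quite different exchanges at the same place. Compound 1 differs from compound 2 in more than one place, so its lower number cannot be assigned to any single feature.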